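This account rests on a few compounds, and the source may have more. Where it says the series, first, only, none or still open, it means among the compounds named here.

Of the compounds shown here, three built on a shared core have been tested in a functional assay on Bel-7402 cells (Homo sapiens) for cytotoxicity, read by MTT assay, with a stated time of 72 h; on this read-out lower numbers stand for stronger inhibition and higher numbers for weaker inhibition. Compound 1 `O=C1C=CCC/C1=C\C(Br)=C\c1ccccc1` reaches only a limit of the assay, > 10000 nM, and no number (the limit of > 10000 nM in this assay, at which 1 of the 3 values shown sits). Compound 2 `O=C1C=CCC/C1=C\C=C\c1ccc(F)cc1` gives 1800 nM in this assay. Compound 3 `COc1ccccc1/C=C/C=C1\CCC=CC1=O` gives 2600 nM in this assay, and the two numbers sit within the usual scatter of each other, so compound 2 stands close to compound 3 rather than apart from it. The unmeasured compound 4 `CN(C)c1ccc(/C=C/C=C2\CCC=CC2=O)cc1` differs from compound 2 by dimethylamino in place of fluoro on an aromatic carbon. Within the data shown here, no measured pair shows this change, so its size is open. The step is expected to be small and toward a higher number, a 1.7-fold higher number from compound 2 to compound 4 (0.22 log units; within the scatter), in this assay. Compound 4 is therefore estimated at 3000 nM, within 1000 nM to 9000 nM.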

Compound 4, half-maximal inhibitory concentration: 900 nM
Beside the measured number, compound 4's estimate is 3.3-fold (0.52 log units) above it, and the stated range ends above it.
By their numbers in this assay, from the lowest: compounds 4, 2 and 3 (each within the scatter of the next, the first and the last beyond it). At a limit, above all of these: compound 1.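

In this assay, among these compounds, the first measured change at this position, dimethylamino in place of fluoro on the aromatic carbon para to a large group, gives a 2.0-fold lower number from compound 2 to compound 4 (0.30 log units; within the scatter) and so leaves the number within the scatter. The larger group, which brings a hydrogen-bond acceptor, therefore stands here in place of a single fluorine with no change beyond the scatter. Nothing in the data shown accounts for this step.

From the compounds shown here alone, whether a carboxylic acid or a primary amine on this same aromatic carbon would keep the number in this range remains open.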